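Nitro in place of trifluoromethyl on the aryl ring

The source may hold more compounds than are shown below. What is called first, only, known or untested is meant among the compounds shown, and "the series" means these compounds.

Measured in a functional assay for inhibition, read by spectrophotometry, with a stated time of 120 min; a lower number here means a stronger inhibitor, a higher number a weaker inhibitor:
- compound 1 `CCOC(=O)N1CCC(=NNC(=O)c2ccc(F)cc2)CC1` gives 65600 nM
- compound 2 `CCOC(=O)N1CCC(=NNC(=O)c2ccc(C(F)(F)F)cc2)CC1` gives 49300 nM

Compound 2 holds the lower of the two numbers in this assay; nearest is compound 1, and the step of a 1.3-fold lower number from compound 1 to compound 2 (0.12 log units; within the scatter) lies within the scatter, so no order between the two can be claimed. Compound 3 `CCOC(=O)N1CCC(=NNC(=O)c2ccc([N+](=O)[O-])cc2)CC1` differs from compound 2 by nitro in place of trifluoromethyl on an aromatic carbon. Going by the values given here, no measured step involves a nitro group; the only measured step, a 1.3-fold lower number from compound 1 to compound 2 (0.12 log units; within the scatter), swaps the group on the same aromatic carbon and stays within the scatter, which bears on compound 3 only in that a swap there has so far moved nothing beyond the noise. For compound 3 the expected step of a 1.1-fold lower number from compound 2 to compound 3 (0.04 log units; within the scatter) is therefore none beyond the scatter. Compound 3 is accordingly estimated at 45000 nM in this assay, with a range from 15000 nM to 150000 nM.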

Compound 3, half-maximal inhibitory concentration: 40200 nM
Compound 3: middle estimate off by 1.1-fold (0.05 log units), on the high side, and the stated range covers the measured number.
By their numbers in this assay, from the lowest: compounds 3, 2 and 1 (each within the scatter of the next).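

In this assay, neither a 1.2-fold lower number from compound 2 to compound 3 (0.09 log units; within the scatter) nor a 1.6-fold lower number from compound 1 to compound 3 (0.21 log units; within the scatter) lies beyond the scatter, so fluoro, trifluoromethyl and nitro on this aromatic carbon cannot be placed in any order. Where a single swap could be read before, there are now three groups, and the result holds even for a replacement that brings hydrogen-bond acceptors where trifluoromethyl has none. No supporting measurement bears on why these groups stay within the scatter of one another.

From the compounds shown here alone, whether an amine, a carboxylic acid or a longer chain on this aromatic carbon would give a step beyond the scatter remains open. So does whether a change elsewhere in the shared core would move the number in this assay further than any swap at this position has so far.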